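A few compounds are considered here, and "the series" means these few. Any claim that something is new, unique, unknown or untested is made for them only; others in the source may bear on it.

In an ADME assay on Vero cells (Chlorocebus sabaeus) for cytotoxicity, read by MTT assay, with a stated time of 72 h (a lower number here means that less compound is tolerated, a higher number that more compound is tolerated), compound 1 (`CCOC(=O)CN1CCN(c2c(F)cc3c(=O)c(C(=O)O)cn(C4CC4)c3c2OC)CC1C`) gives 1000 ug/mL as its result. For its relative compound 2 (`CCOC(=O)CCN1CCN(c2c(F)cc3c(=O)c(C(=O)O)cn(C4CC4)c3c2OC)CC1C`) the entry reads "not determined" (no result reported) and so offers no number to start from. Compound 3 (`COc1c(N2CCN(CCC(C)=O)C(C)C2)c(F)cc2c(=O)c(C(=O)O)cn(C3CC3)c12`) differs from compound 2 at the end of one chain, as methyl in place of ethoxy on a carbonyl carbon shows, with methyl in place of ethoxy on a carbonyl carbon. Going by the values given here, no measured step shows what this change does, so no shift beyond the usual scatter is expected. The only reference for that expectation is compound 1 at 1000 ug/mL. For compound 3 the estimated value is 800 ug/mL within an expected range from 300 ug/mL to 1500 ug/mL in this test.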

Compound 3, half-maximal cytotoxic concentration: 9.84 ug/mL
Compound 3: the middle estimate sits 81-fold (1.91 log units) above what was measured; measured number outside the range, below it.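

In this assay, 2-oxopropyl in place of ethoxycarbonyl on the saturated chain carbon bound to the ring amine nitrogen gives a 100-fold lower number from compound 1 to compound 3 (2.01 log units; beyond the scatter), so the group at this chain end can strongly change how much compound the cells tolerate. The step from compound 2 to compound 3 cannot be read, as compound 2 has no number. Nothing measured here explains the drop. Still open, on these data alone, is how much of the drop would remain with ethoxy to methyl alone, and where a carboxylic acid or an amide at this chain end would fall.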